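The source may hold more compounds than are shown below. What is called first, only, known or untested is meant among the compounds shown, and "the series" means these compounds.

Series notes. Within the data shown here, compound 3 `C#CCNC(=O)/C(C)=C(\C)c1ccccc1` in a toxicity assay on the whole organism (strain Icem-CET (SPF Caw)) for cytotoxicity, with Mus musculus as the target (a higher number here means that more compound is needed for the effect, a lower number that less compound is needed), gives 400 mg/kg, level with compound 1 `C#CCNC(=O)/C(C)=C(\C)c1ccc(OC)cc1`, which in this assay gives 400 mg/kg; these two stand together as the highest of the three numbers so far. Compound 2 `C/C(C(=O)NC1CC1)=C(/C)c1ccc(F)cc1` in this assay gives 200 mg/kg, and the gap between compound 2 and compound 3 lies within the scatter. Compound 4 `C#CCNC(=O)/C(C)=C(\C)c1ccc(F)cc1` is not yet measured. The change from compound 3 is fluoro in place of hydrogen on an aromatic carbon. Among the measured compounds shown here, no measured step covers exactly this change. For the measured compounds named here, the one measured step, no change at the digits printed from compound 1 to compound 3 (within the scatter), also concerns a group on an aromatic carbon and leaves this assay unchanged within the scatter. Compound 2 carries fluoro on the same kind of ring with a different amide, and its number sits within the scatter of compound 3. For compound 4, therefore, no step beyond the scatter is expected in this assay, the estimated step being a 1.3-fold lower number from compound 3 to compound 4 (0.12 log units; within the scatter). Compound 4 is estimated at 300 mg/kg, with a range from 150 mg/kg to 600 mg/kg.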

Compound 4, dose for half-maximal effect: 200 mg/kg
For compound 4 the middle estimate is 1.5-fold (0.18 log units) above the measured one; low and high end bracket the measured number.
By their numbers in this assay, from the lowest: compounds 2, 4, 1 and 3 (each within the scatter of the next).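

In this assay, fluoro on the aromatic carbon para to a large group now has a direct reading against hydrogen (a 2.0-fold lower number from compound 3 to compound 4 (0.30 log units; within the scatter)) and against methoxy (a 2.0-fold lower number from compound 1 to compound 4 (0.30 log units; within the scatter)), so hydrogen, methoxy and fluoro at this position all lie within the scatter of one another. With fluoro held in place, the amide nitrogen can also be read, and propargyl in place of cyclopropyl (no change at the digits printed from compound 2 to compound 4 (within the scatter)) likewise stays within the scatter. No supporting data accompany these numbers, so nothing can be said of what lies behind them.

As far as these compounds go, whether an amine or a carboxylic acid at this position would give a step beyond the scatter stays open. Also open, from the compounds shown here alone, is whether a longer chain in place of propargyl on the amide nitrogen would do so.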